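Series notes: amine substituent on the shared core, maximal response

The compounds below may be only part of what the source reports. "The series", "measured", "known", "first", "only" and "open" are said of these compounds alone.

Measured compounds and values in a functional assay on CHO cells for activation of 5-hydroxytryptamine receptor 1D (Homo sapiens), read by GTPgammaS binding; a higher number here means a larger maximal response, a lower number a smaller maximal response: compound 1 `O=S(=O)(NCC1CCN(CCCc2c[nH]c3ccc(-n4cnnc4)cc23)CC1)c1ccccc1` gives 73%; compound 2 `OCCC(NC1CCN(CCCc2c[nH]c3ccc(-n4cnnc4)cc23)CC1)c1ccccc1` gives 100%; compound 3 `NC(=O)OC[C@H](NC1CCN(CCCc2c[nH]c3ccc(-n4cnnc4)cc23)CC1)c1ccccc1` gives 73%.

Compound 2 stands highest of the three numbers in this assay. The step from the sulfonamide compound was a number 27 percentage points higher from compound 1 to compound 2 (beyond the scatter). The other neighbour, compound 3, lies by a number 27 percentage points lower from compound 2 to compound 3 (beyond the scatter). Both steps are modest, and both sit beyond the scatter.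

Compound 4 `CC(CO)(NC1CCN(CCCc2c[nH]c3ccc(-n4cnnc4)cc23)CC1)c1ccccc1` is the next compound in the series, yet to be measured in this assay. Its difference from compound 2 is 1-(hydroxymethyl)-1-phenylethyl in place of 3-hydroxy-1-phenylpropyl on an amine nitrogen.

Within the data shown here, of the measured steps, only the step from compound 2 to compound 3 bears directly on this change, since it also alters the group on the amine nitrogen while the shared core stays unchanged; it was a number 27 percentage points lower from compound 2 to compound 3 (beyond the scatter). The step from compound 1 to compound 2 changes a different part and gives no guidance. Compound 2 already stands at the top of this small set, so a change at this position is expected either to leave the response within the scatter or to lower it modestly, as compound 3 did. A modest lowering is therefore the working expectation, with the upper end of the range at the level of compound 2.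

For compound 4 in this assay the estimate is 85%, range 65% to 100%.

The step this estimate implies is a number 15 percentage points lower from compound 2 to compound 4 (beyond the scatter), expected as a modest decrease that may still fall within the scatter.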

Compound 4, largest response reached (reported as efficacy), in percent of the reference or control that the assay uses: 59%
Compound 4: middle estimate off by 26 percentage points, on the high side; measured number below the stated range.
By their numbers in this assay, from the lowest: compound 4; then compounds 1 and 3 (each within the scatter of the next); then compound 2.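

In this assay, the same atoms rearranged on the amine nitrogen are enough to change the maximal response: the 3-hydroxy-1-phenylpropyl and 1-(hydroxymethyl)-1-phenylethyl groups match in heavy atoms, donors and acceptors, yet the result is a number 41 percentage points lower from compound 2 to compound 4 (beyond the scatter) and the step is large. Compound 4 also falls under both other neighbours, with a number 14 percentage points lower from compound 3 to compound 4 (beyond the scatter) and with a number 14 percentage points lower from compound 1 to compound 4 (beyond the scatter) as well, so this change costs more than the swap to 2-(carbamoyloxy)-1-phenylethyl did. Among these compounds, at this position, therefore, the arrangement of the substituent matters and not only its composition, which the earlier compounds, all differing in composition, could not show.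

Still open, on these data alone, is which feature of the rearrangement carries the loss, since the branched carbon and the shorter hydroxyl-bearing chain change together here; a 2-hydroxy-1-phenylethyl group would separate the two, and a 1-(aminomethyl)-1-phenylethyl group would test whether the hydroxyl itself is needed. Nothing measured on these compounds accounts for the drop.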